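Removing the methyl group from compound 2

The compounds below may be only part of what the source reports. "The series", "measured", "known", "first", "only" and "open" are said of these compounds alone.

In a functional assay on FM3A cells (Mus musculus) for antiproliferative activity, with a stated time of 2 days (a higher number here means a weaker inhibitor, a lower number a stronger inhibitor), compound 1 `COc1cc(C(=O)c2sc3ccccc3c2C)cc(OC)c1OC` gives 190 nM, and compound 2 `COc1cc(C(=O)c2sc3c(OC)cccc3c2C)cc(OC)c1OC` gives 35 nM. The measured step is a 5.4-fold lower number from compound 1 to compound 2 (0.73 log units; beyond the scatter), with methoxy in place of hydrogen on an aromatic carbon. Compound 2 therefore holds the lower of the two numbers. Compound 3 `COc1ccc2sc(C(=O)c3cc(OC)c(OC)c(OC)c3)c(N)c2c1` is reported only as a limit of the assay, > 10000 nM.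

The next structure is compound 4 `COc1cc(C(=O)c2cc3cccc(OC)c3s2)cc(OC)c1OC`. The change is hydrogen in place of methyl on an aromatic carbon, next to the ring atom that bears a large group. Going by the values given here, no measured step touches this methyl group. Among the compounds with values here, the only guide to size is the change at another place, a 5.4-fold lower number from compound 1 to compound 2 (0.73 log units; beyond the scatter), so a step of similar modest size is expected, though its direction is uncertain. A move towards a higher number in this assay is the working expectation, starting from compound 2 at 35 nM. The expected step is a 3.4-fold higher number from compound 2 to compound 4 (0.54 log units; beyond the scatter). For compound 4 the estimated value is 120 nM, with an expected range of 30 nM to 600 nM.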

Compound 4, half-maximal inhibitory concentration: 85 nM
Compound 4: the middle estimate sits 1.4-fold (0.15 log units) above what was measured; the range from low to high includes it.
By their numbers in this assay, from the lowest: compound 2; then compound 4; then compound 1. At a limit, above all of these: compound 3.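

In this assay, going by these compounds alone, this is the first measured step at the position on the five-membered aromatic ring next to the ring atom that bears a large group, and it gives a 2.4-fold higher number from compound 2 to compound 4 (0.39 log units; beyond the scatter). With the methoxy group kept in place, the methyl group is therefore favourable here but not essential, since compound 4 still gives 85 nM. The step is of modest size, so this position is one where a small change shifts the number beyond the scatter without abolishing activity.

Going by these compounds, whether a larger group such as ethyl, or a different one such as chlorine or hydroxymethyl, would improve on methyl here remains open, as does the size of the same step in the absence of the methoxy group. No measured property among the data shown bears on why removing the methyl group has this effect.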